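The source may report more compounds than this note shows. Statements on the series, on what has been measured and on what is new or still open speak of the compounds shown alone.

Working notes on the series. Among the measured compounds shown here, compound 1 `COc1cc(-c2nnc3n2NC(CC(=O)c2ccc(C)cc2)(c2ccccc2)S3)cc(OC)c1OC` is the only member with a numerical reading in a functional assay on MKN-45 cells (Homo sapiens) for cytotoxicity, read by MTT assay, with a stated time of 48 h (a higher number here means a weaker inhibitor, a lower number a stronger inhibitor), where compound 1 gives 7470 nM. For the measured compounds named here, compound 2 `CCOC(=O)CC1(c2ccccc2)Nn2c(nnc2-c2cc(OC)c(OC)c(OC)c2)S1` is the one other measured member. In this assay compound 2 returns only a limit, > 200000 nM, not a number. Going by the values given here, the single measured step, an at least 26-fold higher number from compound 1 to compound 2 (1.42 log units; beyond the scatter), concerns the carbonyl substituent and runs up to the limit of > 200000 nM in this assay, at which 1 of the 2 values shown sits; it says nothing about the saturated ring carbon that carries the phenyl group.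

Compound 3 `COc1ccc(C2(CC(=O)c3ccc(C)cc3)Nn3c(nnc3-c3cc(OC)c(OC)c(OC)c3)S2)c(OC)c1` changes that ring carbon: 2,4-dimethoxyphenyl in place of phenyl on a saturated ring carbon. No measured step touches this position, so no shift beyond the scatter can be argued from the numbers shown, in either direction, and the carbonyl side that drove the loss in compound 2 is kept unchanged from compound 1. The working expectation for compound 3 is therefore a step of about a 1.0-fold higher number from compound 1 to compound 3 (0.00 log units; within the scatter) in this assay, essentially none beyond the scatter. On that basis compound 3 is estimated at 7500 nM in this assay, with a range of 2000 nM to 30000 nM.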

Compound 3, half-maximal inhibitory concentration: 13800 nM
Estimate against measurement, compound 3: 1.8-fold (0.26 log units) below, and the stated range covers the measured number.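

In this assay, the saturated ring carbon that carries the phenyl group now has a measured step of its own: a 1.8-fold higher number from compound 1 to compound 3 (0.27 log units; within the scatter), for 2,4-dimethoxyphenyl in place of phenyl. The earlier compounds shown here gave no reading at this position, and this replacement, although it brings in the two methoxy groups, leaves the result within the usual scatter of the assay, so the position accepts this aromatic ring with no change that can be told apart from repeat measurement. Among the compounds shown here, compound 3 also has a numerical reading, which places this change on a different footing from the carbonyl replacement in compound 2, the only compound here that gives no number: the limit of > 200000 nM in this assay, at which 1 of the 3 values shown sits.

On these data alone, one substituted ring says little about the position as a whole, so it remains open whether a single methoxy group, an amine or a carboxylic acid on that aromatic ring would also stay within the scatter. The carbonyl side is equally thin, as only the 4-methylphenyl and ethoxy groups are shown there, and a replacement such as a longer chain on that carbonyl carbon remains unread.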